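Swapping the aromatic amide for an aliphatic amine

A few compounds are considered here, and "the series" means these few. Any claim that something is new, unique, unknown or untested is made for them only; others in the source may bear on it.

Within the data shown here, compound 1 `CC(C)(C)C(=O)N1Cc2c(NC(=O)c3ccncc3)n[nH]c2C1(C)C` gives 110 nM in a functional assay on A2780 cells (Homo sapiens) for antiproliferative activity, read by fluorescence, with a stated time of 72 h (on this read-out lower numbers stand for stronger inhibition and higher numbers for weaker inhibition), and holds the lowest of the two numbers so far. Compound 2 `CN1CCC(C(=O)N2Cc3c(NC(=O)c4cccc(F)c4)n[nH]c3C2(C)C)CC1` gives 200 nM in this assay, a value within the scatter of that of compound 1. Compound 3 `CN(C)CC(=O)Nc1n[nH]c2c1CN(C(=O)C(C)(C)C)C2(C)C` has not yet been measured. It differs from compound 1 at the carbonyl carbon whose other neighbour is the amide-type nitrogen: (dimethylamino)methyl in place of pyridin-4-yl on a carbonyl carbon. Compound 3 is expected to show a weaker result in this assay, with the step of a 14-fold higher number from compound 1 to compound 3 (1.13 log units; beyond the scatter) running beyond the scatter, because compound 1 with its pyridin-4-yl group gives 110 nM. For compound 3 the estimate is 1500 nM, with a range from 300 nM to 8000 nM.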

Compound 3, half-maximal inhibitory concentration: 580 nM
For compound 3 the middle estimate is 2.6-fold (0.41 log units) above the measured one, and the stated range covers the measured number.
By their numbers in this assay, from the lowest: compounds 1 and 2 (each within the scatter of the next); then compound 3.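

In this assay the change on this carbonyl carbon, (dimethylamino)methyl in place of pyridin-4-yl, gives a 5.3-fold higher number from compound 1 to compound 3 (0.72 log units; beyond the scatter), so the group held here does affect the result. The step is modest, and compound 3 keeps a measurable value with no ring in this group. Nothing available accounts for the step. From the compounds shown here alone, whether the ring or the amine matters more remains open, and a cyclohexyl group or a longer chain ending in dimethylamino on this carbonyl carbon would help to separate the two.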